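The source may report more compounds than this note shows. Statements on the series, on what has been measured and on what is new or still open speak of the compounds shown alone.

Three compounds share a cinnamamide linked to a trimethoxybenzoyl-bearing aniline. Compound 1 `COc1ccc(C(=O)c2cc(OC)c(OC)c(OC)c2)cc1NC(=O)/C=C/c1ccc(F)cc1` in a functional assay on HeLa cells (Homo sapiens) for cytotoxicity, read by MTT assay, with a stated time of 72 h (on this read-out higher numbers stand for weaker inhibition and lower numbers for stronger inhibition), gives 60 nM. Compound 2 `COc1cc(/C=C/C(=O)Nc2cc(C(=O)c3cc(OC)c(OC)c(OC)c3)ccc2OC)ccc1F` in this assay gives 13600 nM. Compound 3 `COc1cc(C(=O)c2cc(OC)c(OC)c(OC)c2)cc(NC(=O)/C=C/c2cc(OC)c(OC)c(OC)c2)c1OC` in this assay gives 2500 nM. The difference between the cores of compound 2 and compound 3 is not broken down here.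

Going by the values given here, the one counted change among the measured compounds is hydrogen in place of methoxy on an aromatic carbon, which made a 230-fold lower number from compound 2 to compound 1 (2.36 log units; beyond the scatter). Compound 3 stands second highest of the three; its number lies between those of compound 2 and compound 1, nearer to compound 2.

Compound 4 `COc1ccc(/C=C/C(=O)Nc2cc(C(=O)c3cc(OC)c(OC)c(OC)c3)cc(OC)c2OC)cc1OC` has not yet been measured. It differs from compound 3 by hydrogen in place of methoxy on an aromatic carbon. Among the compounds with values here, this is the same kind of change as the one from compound 2 to compound 1, but the surroundings are not the same: there the carbon was ortho to a fluoro group and meta to a large group, here it is ortho to a methoxy group, meta to a large group and meta to a methoxy group. The expected step is a 5.0-fold lower number from compound 3 to compound 4 (0.70 log units; beyond the scatter), smaller than the earlier one, because the step of a 230-fold lower number from compound 2 to compound 1 (2.36 log units; beyond the scatter) was made in a different setting and only once. Compound 4 is therefore expected to give about 500 nM in this assay, with an estimated range from 80 nM to 3000 nM.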

Compound 4, half-maximal inhibitory concentration: 2700 nM
Compound 4: middle estimate off by 5.4-fold (0.73 log units), on the low side; low and high end bracket the measured number.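

In this assay, going from 3,4,5-trimethoxyphenyl to 3,4-dimethoxyphenyl gives a 1.1-fold higher number from compound 3 to compound 4 (0.03 log units; within the scatter), so the two compounds cannot be told apart on this read-out. Replacing a methoxy group with hydrogen therefore does not carry over from one core to the other in this series as a step of fixed size, and the large gain seen on the first core cannot be assumed on the second: the same change on two cores in this assay, a 230-fold lower number (2.36 log units; beyond the scatter) from compound 2 to compound 1 and a 1.1-fold higher number (0.03 log units; within the scatter) from compound 3 to compound 4, 240-fold (2.39 log units) apart, beyond the scatter of two such steps Each step rests on a single pair of compounds, and the two pairs do not show which feature of the cores or of the surroundings of the changed carbon sets the steps apart, nor do they show how the change would behave on any other core.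

The compounds shown leave open whether either step would hold on further cores that carry the same trimethoxybenzoyl group, or whether the step on the second core would stay within the scatter if the ring also carried a fluoro group. They also leave open what an amine, a hydroxyl group, a chlorine atom or a longer alkoxy chain would give in place of the methoxy group on the same aromatic carbon in this assay.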